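The source may hold more compounds than are shown below. What is called first, only, known or untested is meant among the compounds shown, and "the series" means these compounds.

Going by the values given here, compound 2 `C=CC(=O)Nc1cc(Nc2ncc3ncn(-c4ccc(C(C)C)cc4)c3n2)c(OC)cc1N(C)CCN(C)C` in an ADME assay on HT-29 cells (Homo sapiens) for cytotoxicity, read by MTT assay, with a stated time of 72 h (a lower number here means a stronger inhibitor, a higher number a weaker inhibitor), gives 15300 nM, the upper one of only two numbers, and it lies within the scatter of its neighbour: compound 1 `C=CC(=O)Nc1cc(Nc2ncc3ncn(-c4ccccc4)c3n2)c(OC)cc1N(C)CCN(C)C` gives 8080 nM, with a 1.9-fold higher number from compound 1 to compound 2 (0.28 log units; within the scatter). Compound 3 `C=CC(=O)Nc1cc(Nc2ncc3ncn(-c4ccc(CC)cc4)c3n2)c(OC)cc1N(C)CCN(C)C` differs from compound 2 by hydrogen in place of methyl on a saturated chain carbon bound to an aromatic carbon and a saturated chain carbon. Among the compounds with values here, the single measured step that bears on this change, the one from compound 1 to compound 2, stayed within the scatter, so trimming one methyl from the isopropyl is expected to shift the number little if at all, giving a 1.4-fold lower number from compound 2 to compound 3 (0.14 log units; within the scatter). Compound 3 is therefore estimated at 11000 nM, with a range from 5000 nM to 25000 nM.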

Compound 3, half-maximal inhibitory concentration: 8180 nM
Compound 3: the middle estimate sits 1.3-fold (0.13 log units) above what was measured; low and high end bracket the measured number.
By their numbers in this assay, from the lowest: compounds 1, 3 and 2 (each within the scatter of the next).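

In this assay, going from isopropyl to ethyl gives a 1.9-fold lower number from compound 2 to compound 3 (0.27 log units; within the scatter), and ethyl in place of hydrogen on the aromatic carbon gives a 1.0-fold higher number from compound 1 to compound 3 (0.01 log units; within the scatter). Hydrogen, ethyl and isopropyl at this position now make a series of three compounds with every step inside the scatter, which the single earlier step could not show. No outside information bears on this result. Still open, from the compounds shown here alone, is whether an amine, a carboxylic acid or a longer chain at this position would give a step beyond the scatter.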